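Working notes: aryl swap on the triazole nitrogen

A few compounds are considered here, and "the series" means these few. Any claim that something is new, unique, unknown or untested is made for them only; others in the source may bear on it.

Measured compounds:
compound 1 `O=C1Nc2ccccc2/C1=C/c1ccc(-c2cn(-c3ccc(Cl)cc3)nn2)cc1`: 18200 nM
compound 2 `N#Cc1ccccc1-n1cc(-c2ccc(/C=C3\C(=O)Nc4ccccc43)cc2)nn1`: 19700 nM
compound 3 `O=C1Nc2ccc(F)cc2C1=Cc1ccc(-c2cn(-c3ccc(Cl)cc3)nn2)cc1`: 19600 nM

All three numbers come from an ADME assay on HUVEC cells (Homo sapiens) for inhibition, read by CCK-8 assay, with a stated time of 24 h, in the presence of a further agent that is not named here (a higher number here means a weaker inhibitor, a lower number a stronger inhibitor), and sit within the scatter of one another, so no order among them is claimed. Compound 2 differs from compound 1 by 2-cyanophenyl in place of 4-chlorophenyl on an aromatic nitrogen; that step was a 1.1-fold higher number from compound 1 to compound 2 (0.03 log units; within the scatter). Compound 3 carries a different core from compound 1; the difference between the two cores is not broken down here.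

Compound 4 `N#Cc1ccccc1-n1cc(-c2ccc(C=C3C(=O)Nc4ccc(F)cc43)cc2)nn1` is not yet measured in this assay. It differs from compound 3 by 2-cyanophenyl in place of 4-chlorophenyl on an aromatic nitrogen, the same change as from compound 1 to compound 2, and the expectation rests on that earlier step alone. The step from compound 1 to compound 2 lay within the scatter. On that basis the expected step is a 1.1-fold higher number from compound 3 to compound 4 (0.03 log units; within the scatter). Compound 4 is therefore estimated at 21000 nM, with a likely range from 12000 nM to 38000 nM.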

Compound 4, half-maximal inhibitory concentration: > 20000 nM
Compound 4: a limit, no number; the forecaster's own chance of this, stated with the estimate: 5%; the middle value does not contradict the limit.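

In this assay compound 4 gives > 20000 nM, which is a limit of the assay and not a number. The swap of 4-chlorophenyl for 2-cyanophenyl on the aromatic nitrogen gives an at least 1.0-fold higher number from compound 3 to compound 4 (0.00 log units; that floor lies within the scatter), and set beside the earlier step it reads: the same change on two cores in this assay, a 1.1-fold higher number (0.03 log units; within the scatter) from compound 1 to compound 2 and an at least 1.0-fold higher number (0.00 log units; that floor lies within the scatter) from compound 3 to compound 4; the limit leaves it open whether they differ. Nothing here contradicts the change carrying over from the core of compound 1 to the core of compound 3, yet carry-over is not shown, as the size of the step on the core of compound 3 remains unread.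

Only 4-chlorophenyl and 2-cyanophenyl appear on that aromatic nitrogen. Open, on these data alone, is how a phenyl ring bearing an amine or a carboxylic acid, or a longer alkyl chain in place of the ring, would read on either core.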